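The compounds below may be only part of what the source reports. "The series", "measured", "known", "first", "only" and "open" are said of these compounds alone.

In a functional assay on OVCAR-8 cells (Homo sapiens) for inhibition (on this read-out lower numbers stand for stronger inhibition of growth and higher numbers for weaker inhibition of growth), compound 1 (`COc1ccc(-n2cnnc2-c2cc(OC)c(OC)c(OC)c2)cc1`) gives 4790 nM and compound 2 (`COc1cc(-c2nncn2-c2ccc(N(C)C)cc2)cc(OC)c1OC`) gives 2570 nM. Going by the values given here, compound 1 therefore stands level with the only other measured compound, since the measured step is a 1.9-fold lower number from compound 1 to compound 2 (0.27 log units; within the scatter). Compound 3 (`COc1ccc(-n2cnnc2-c2cc(OC)c(OC)c(OC)c2)cc1O`) keeps the core of compound 1 and carries one change: hydroxy in place of hydrogen on an aromatic carbon. The new hydroxy sits ortho to a methoxy group. Among the compounds with values here, the single measured step bears on this only weakly, since it replaces a methoxy group and not a hydrogen, and no measured step adds a hydroxy. The expectation in this assay therefore rests on the structural change alone and stays uncertain, leaning towards stronger inhibition of growth. The expected change is a 19-fold lower number from compound 1 to compound 3 (1.28 log units; beyond the scatter), well beyond the scatter. For compound 3 the estimated value is 250 nM, with an expected range from 25 nM to 2500 nM.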

Compound 3, concentration for 50% growth inhibition: 977 nM
Beside the measured number, compound 3's estimate is 3.9-fold (0.59 log units) below it, within the range that was stated.
By their numbers in this assay, from the lowest: compound 3; then compounds 2 and 1 (each within the scatter of the next).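

In this assay, hydroxy in place of hydrogen on an aromatic carbon, ortho to a methoxy group and meta to a large group, gives a 4.9-fold lower number from compound 1 to compound 3 (0.69 log units; beyond the scatter). This place on the ring, which holds only hydrogen in compound 1, therefore responds to a small change beyond the scatter, whereas dimethylamino in place of methoxy gives a 1.9-fold lower number from compound 1 to compound 2 (0.27 log units; within the scatter). Nothing available here bears on why the added hydroxy goes with the lower number.

Whether this step is specific to hydroxy stays open, as the compounds shown do not tell how an amine, a fluorine or a carboxylic acid at the same place would compare. They also leave open whether the same hydroxy, added to compound 2, would give a step of similar size.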